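A few compounds are considered here, and "the series" means these few. Any claim that something is new, unique, unknown or untested is made for them only; others in the source may bear on it.

In a functional assay on U-87MG ATCC cells (Homo sapiens) for cytotoxicity, read by MTT assay, with a stated time of 48 h (a lower number here means a stronger inhibitor, a higher number a weaker inhibitor), compound 1 `C/C(=N/NC(=S)Nc1ccccc1)c1ccccn1` gives 1.4 nM. Compound 2 `C/C(=N/NC(=S)Nc1cccc([N+](=O)[O-])c1)c1ccccn1` gives 69 nM and compound 3 `C/C(=N/NC(=S)Nc1cccc(I)c1)c1ccccn1` gives 84 nM. These two stand level, with a 1.2-fold higher number from compound 2 to compound 3 (0.09 log units; within the scatter), and both lie far above compound 1, with a 49-fold higher number from compound 1 to compound 2 (1.69 log units; beyond the scatter) and a 60-fold higher number from compound 1 to compound 3 (1.78 log units; beyond the scatter). Compound 4 `C/C(=N\NC(=S)Nc1cccc([N+](=O)[O-])c1)c1ccccn1` is the counterpart of compound 2: the two compounds have the same atoms and bonds and differ only in configuration as drawn: 1 of 1 stereo elements differ; a double bond is drawn Z in compound 2 and E in compound 4. Among the measured compounds shown here, none of the measured steps changes a configuration. Each only exchanges a group on an aromatic carbon, so their large sizes give no direct measure of this change, and the data show no direction for it. No step beyond the scatter is therefore expected in this assay. The estimated step is a 1.0-fold higher number from compound 2 to compound 4 (0.01 log units; within the scatter). Compound 4 is expected at 70 nM, within an estimated range of 20 nM to 220 nM.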

Compound 4, half-maximal inhibitory concentration: 69 nM
Estimate against measurement, compound 4: 1.0-fold (0.01 log units) above; the measured number falls inside the stated range.
By their numbers in this assay, from the lowest: compound 1; then compounds 2, 4 and 3 (each within the scatter of the next).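

In this assay, among the compounds shown here, this pair gives the first direct reading of the double bond's configuration, with no change at the digits printed from compound 2 to compound 4 (within the scatter). With a nitro group on the aromatic ring, moving from Z to E as drawn therefore leaves the number in place, unlike the large steps seen when the aromatic group was exchanged. The comparison is a clean one, with nothing else altered: the fact that compounds 2 and 4 differ only in the configuration as drawn

From the compounds shown here alone, whether the configuration is equally silent with the hydrogen of compound 1 or the iodo group of compound 3 stays open. So does the effect of an amine or a carboxylic acid on that aromatic carbon.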